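The source may hold more compounds than are shown below. What is called first, only, known or untested is meant among the compounds shown, and "the series" means these compounds.

Compound 1 `CCOC(=O)c1c(C)nc(-c2ccccc2C#N)n1OC` and compound 2 `CCOC(=O)c1c(C)nc(-c2cccc(C#N)c2)n1OCC(N)=O` share the same core but differ in more than one place, so no single step can be read between them. In a functional assay on a cell-free system (plasma, Oryctolagus cuniculus) for inhibition, with stated times of 5 min, 1 min and 6 min (a lower number here means a stronger inhibitor, a higher number a weaker inhibitor), compound 1 gives 14900 nM. For compound 2 this assay reports only a limit, > 30000 nM, which marks the edge of what the test can return rather than a measured number (the limit of > 30000 nM in this assay, at which 1 of the 2 values shown sits). Compound 3 `CCOC(=O)c1c(C)nc(-c2cccc(C#N)c2)n1OCc1ccc(C)cc1` arises from compound 2 by one change: 4-methylphenyl in place of carbamoyl on a saturated chain carbon bound to an oxygen on an aromatic ring. Because compound 2 sits at the limit of > 30000 nM in this assay, at which 1 of the 2 values shown sits, the starting point of this step is known only as a limit, and no measured step of this kind exists among these compounds to guide the direction. The expected step is an at least 1.5-fold lower number from compound 2 to compound 3 (0.17 log units; that floor lies within the scatter), a modest move that may not exceed the scatter. Compound 3 is therefore estimated at 20000 nM, with a range from 5000 nM to 60000 nM.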

Compound 3, half-maximal inhibitory concentration: 6310 nM
The estimate for compound 3 lay 3.2-fold (0.50 log units) above the measured number; the measured number falls inside the stated range.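

In this assay, putting 4-methylphenyl in place of carbamoyl on a saturated chain carbon bound to an oxygen on an aromatic ring gives an at least 4.7-fold lower number from compound 2 to compound 3 (0.67 log units; beyond the scatter). For the compounds shown here, this is the first step that can be read, and it shows that the number responds to what is placed at this position. The size of the step is only a floor because the value for compound 2 is a limit: the limit of > 30000 nM in this assay, at which 1 of the 3 values shown sits.

The change removes the carbamoyl group with its hydrogen-bond donor and acceptor and adds an aromatic ring in a single move, so the compounds shown cannot separate these parts. Going by these compounds alone, how a plain phenyl, an amine or a carboxylic acid would fare at this position remains open, and compound 1 differs from the others in more than one place, so no step to it can be read.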